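Swapping the aryl substituent in a phenethyl urea series

The source may hold more compounds than are shown below. What is called first, only, known or untested is meant among the compounds shown, and "the series" means these compounds.

Three ureas sharing one core have been measured in an ADME assay on the whole organism with Oryza sativa as the target, tested at 10 uM; on this read-out higher numbers stand for a weaker effect at the one concentration tested and lower numbers for a stronger effect. Compound 1 `Cc1cccc(NC(=O)N[C@H](C)c2ccccc2)c1` gives 47%. Compound 2 `CCc1cccc(NC(=O)N[C@H](C)c2ccccc2)c1` gives 36%, and compound 3 `CC(C)c1cccc(NC(=O)N[C@H](C)c2ccccc2)c1` gives 44%. Among these three numbers compound 3 stands second highest: its nearest neighbour is compound 1, with a difference of a number 3 percentage points lower from compound 1 to compound 3 (within the scatter), and its furthest is compound 2, with a difference of a number 8 percentage points higher from compound 2 to compound 3 (within the scatter), both of which sit inside the usual scatter. Among the measured compounds shown here, the one change that widens the group on the aromatic carbon, from methyl to isopropyl, thus left this read-out essentially unchanged.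

Compound 4 `C[C@@H](NC(=O)Nc1cccc(C(F)(F)F)c1)c1ccccc1` is not yet measured. It differs from compound 3 by trifluoromethyl in place of isopropyl on an aromatic carbon. For the measured compounds named here, the only comparison that bears on this position is the step from compound 1 to compound 3, which was small, so no movement beyond the scatter is expected in this assay. The estimate for compound 4 is therefore 44%, with a range from 28% to 60%, corresponding to an expected step of no change at the digits printed from compound 3 to compound 4 (within the scatter).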

Compound 4, a percentage reported as activity, at one concentration (the size of the read-out at that concentration, not a potency): 70%
Estimate against measurement, compound 4: 26 percentage points below, and the stated range ends below it.
By their numbers in this assay, from the lowest: compounds 2, 3 and 1 (each within the scatter of the next, the first and the last beyond it); then compound 4.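

The position proved more sensitive than the alkyl groups had suggested: with trifluoromethyl on this aromatic carbon, this assay shows a number 26 percentage points higher from compound 3 to compound 4 (beyond the scatter), along with a number 23 percentage points higher from compound 1 to compound 4 (beyond the scatter) and a number 34 percentage points higher from compound 2 to compound 4 (beyond the scatter). Compound 4 therefore has the weakest effect of the four, and each of its steps lies beyond the scatter, so the change from an alkyl group to trifluoromethyl matters here in a way the methyl, ethyl and isopropyl compounds could not reveal. Nothing available explains why this swap weakens the effect.

As far as these compounds go, it remains open whether this result is specific to trifluoromethyl or would extend to a chlorine atom, a nitrile, a methoxy group or an amine on the same carbon. The compounds shown also leave open whether trifluoromethyl would have the same effect on another aromatic carbon of this ring.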